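The source may report more compounds than this note shows. Statements on the series, on what has been measured and on what is new or still open speak of the compounds shown alone.

For the measured compounds named here, in a functional assay on the whole organism (strain Sprague-Dawley) for inhibition, with Rattus norvegicus as the target, with a stated time of 10 min (a lower number here means that less compound is needed, a higher number that more compound is needed for the effect), compound 1 (`CCOC(=O)c1cnc(-c2ccccc2OC(C)C)[nH]c1=O`) gives 2 mg/kg and compound 2 (`CCOC(=O)c1cnc(-c2ccccc2OCC(C)C)[nH]c1=O`) gives 3 mg/kg in the same test, so compound 2 stands level with its only measured neighbour. Compound 3 (`CCOC(=O)c1cnc(-c2ccccc2SCC)[nH]c1=O`) differs from compound 2 by (ethylsulfanyl in place of isobutoxy on an aromatic carbon): ethylsulfanyl in place of isobutoxy on an aromatic carbon. Going by the values given here, the only measured step (a 1.5-fold higher number from compound 1 to compound 2 (0.18 log units; within the scatter)) swaps one chain on oxygen for another, and no measured compound carries sulfur, so no step beyond the scatter is expected in this assay and no direction can be argued. The expected step is (no change at the digits printed from compound 2 to compound 3 (within the scatter)) with no shift beyond the scatter. Compound 3 is therefore expected at 3 mg/kg within an estimated range of 1 mg/kg to 8 mg/kg in this test.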

Compound 3, dose for 50% inhibition: > 5 mg/kg
Compound 3 was reported as a limit; the forecaster's own chance of this, stated with the estimate: 3%; at least 1.6-fold (0.22 log units) between middle value and limit.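

In this assay compound 3 is reported only as a limit, not as a number: the limit of > 5 mg/kg in this assay, at which 1 of the 3 values shown sits. For the compounds shown here, at this aromatic carbon, ortho to a large group, ethylsulfanyl gives the first change that clears the scatter, with an at least 2.5-fold higher number from compound 1 to compound 3 (0.39 log units; beyond the scatter). Against the isobutoxy chain the same group gives only an at least 1.6-fold higher number from compound 2 to compound 3 (0.22 log units; that floor lies within the scatter), so that step alone shows no clear change.

On these data alone, how far compound 3 lies past its limit stays open. So does whether the shift follows the sulfur or the shorter chain, which an ethoxy group or a longer chain on sulfur would separate.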